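Chloro to hydrogen on the benzyl amide of compound 3

The source may hold more compounds than are shown below. What is called first, only, known or untested is meant among the compounds shown, and "the series" means these compounds.

Compound 3 `C=CC1=C(C(=O)NCc2ccc(Cl)cc2)C(c2ccc(F)cc2)OC1` sits at the limit of a functional assay on SW480 cells (Homo sapiens) for cytotoxicity, read by MTT assay, with a stated time of 24 h; a higher number here means a weaker inhibitor, a lower number a stronger inhibitor: its value of > 100000 nM is a limit, not a number. Compound 1 `C=CC1=C(C(=O)NCCC)C(c2ccc(F)cc2)OC1` likewise returns only a limit, > 100000 nM. Among the measured compounds shown here, the one measured step touching compound 3, a step that the two limits leave unreadable from compound 1 to compound 3, cannot be sized because of the limit of > 100000 nM in this assay, at which 2 of the 3 values shown sit. Compound 2 `C=CC1=C(C(=O)NCc2ccccc2)C(c2ccc(OC)cc2)OC1`, which also bears benzyl, gives 39500 nM in this assay. Compound 4 `C=CC1=C(C(=O)NCc2ccccc2)C(c2ccc(F)cc2)OC1` differs from compound 3 by hydrogen in place of chloro on an aromatic carbon. For the measured compounds named here, no measured step bears on this change, so the data give no direction for it; the limit on compound 3 leaves compound 4 open to remain a limit or to yield a number. The step of an at least 1.4-fold lower number from compound 3 to compound 4 (0.15 log units; that floor lies within the scatter) is therefore only an estimate. Compound 4 is estimated at 70000 nM, between 25000 nM and 200000 nM.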

Compound 4, half-maximal inhibitory concentration: > 100000 nM
Compound 4: only a limit was reported; the forecaster's own chance of this, stated with the estimate: 45%; at least 1.4-fold (0.15 log units) between middle value and limit.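

In this assay compound 4 gives > 100000 nM, a limit and not a number, so 4-chlorobenzyl to benzyl does not by itself bring a measurable value with fluoro on the aromatic ring. Among the compounds shown here, with benzyl held constant, fluoro in place of methoxy gives an at least 2.5-fold higher number from compound 2 to compound 4 (0.40 log units; beyond the scatter), the first readable step. The steps from compound 1 and compound 3 to compound 4 cannot be read: the limit of > 100000 nM in this assay, at which 3 of the 4 values shown sit.

Open, as far as these compounds go, is whether methoxy also yields a number with the 4-chlorobenzyl amide of compound 3 or the chain amide of compound 1. Also open, from the compounds shown here alone, is how a hydroxyl or a dimethylamino group in place of methoxy would read.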